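Removing the Methyl from the Sulfonamide Aryl of Compound 2

The source may report more compounds than this note shows. Statements on the series, on what has been measured and on what is new or still open speak of the compounds shown alone.

Three members of this series have been tested in a functional assay on the whole organism for inhibition, with Mus musculus as the target, with stated times of 30 min and 2 h, at a dose of 10 mg/kg by the intraperitoneal route; on this read-out lower numbers stand for less inhibition and higher numbers for more inhibition at the one dose given (going by the name of the read-out). Compound 1 `Cc1ccc(S(=O)(=O)NCc2ccc(CNC(=O)c3ccc(F)cc3)cc2)cc1` gives 75%, compound 2 `Cc1ccc(S(=O)(=O)NCc2ccc(CNC(=O)c3ccccc3Cl)cc2)cc1` gives 26%, and compound 3 `COc1ccccc1C(=O)NCc1ccc(CNS(=O)(=O)c2ccc(C)cc2)cc1` is reported as "not active" (no number reported). Within the data shown here, compound 2 thus stands lowest of the two numbers, with compound 1 the nearest; the single measured step, a number 49 percentage points lower from compound 1 to compound 2 (beyond the scatter), is large and lies beyond the scatter, but it concerns the aryl on the carbonyl carbon.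

Compound 4 `O=C(NCc1ccc(CNS(=O)(=O)c2ccccc2)cc1)c1ccccc1Cl` differs from compound 2 by hydrogen in place of methyl on an aromatic carbon. Among the measured compounds shown here, no measured step touches this part of the molecule, so nothing indicates a shift beyond the scatter in this assay. Compound 4 is therefore expected to show no change at the digits printed from compound 2 to compound 4 (within the scatter), giving an estimated 26% within a range of 8% to 45%.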

Compound 4, a percentage reported as inhibition, in the whole organism at one dose (the size of the read-out at that dose, not a potency): "not active" (no number reported)
The entry for compound 4 holds no number; no gap can be computed for the estimate.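

Among these compounds, compound 4 is reported without a number, so no step from compound 2 to compound 4 can be read. The compounds shown leave open how far phenyl in place of 4-methylphenyl shifts the inhibition. Nothing available bears on this result.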